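Benzyl amide in place of an aryl amide: cytotoxicity

The source may report more compounds than this note shows. Statements on the series, on what has been measured and on what is new or still open speak of the compounds shown alone.

Compound 1 `COc1ccc(NC(=O)c2cccc(/C=C3\CC(=O)N(c4ccccc4)C3=O)c2)c(C)c1`: in an ADME assay on HCT-116 cells (Homo sapiens) for cytotoxicity, read by MTT assay, with a stated time of 72 h (on this read-out higher numbers stand for weaker inhibition and lower numbers for stronger inhibition), compound 1 gives > 100000 nM, which is a limit of the assay rather than a number.
Compound 2 `COc1cc(NC(=O)c2cccc(/C=C3\CC(=O)N(c4ccccc4)C3=O)c2)cc(OC)c1OC`: compound 2 gives > 100000 nM, also a limit of the assay.
Compound 3 `CCCCCN1C(=O)C/C(=C\c2cccc(C(=O)Nc3ccc(C)cc3)c2)C1=O`: compound 3 gives > 100000 nM, again a limit of the assay.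

Compound 1 therefore stands nowhere in particular on the numbers shown: its result is only a limit, and the two further results are limits as well, so no order among the three can be read. The common picture is the limit of > 100000 nM in this assay, at which 3 of the 3 values shown sit.

Compound 4 `O=C(NCc1ccccc1)c1cccc(/C=C2\CC(=O)N(c3ccccc3)C2=O)c1` differs from compound 1 in one place: benzyl in place of 4-methoxy-2-methylphenyl on an amide-type nitrogen. For the measured compounds named here, no step between measured compounds exists to calibrate this change. Given that every measured compound sits at the limit of > 100000 nM in this assay, at which 3 of the 3 values shown sit, the writer expects no step beyond the usual scatter, in either direction, from compound 1 to compound 4: a step that the limit leaves unreadable from compound 1 to compound 4. For compound 4 the expected result in this assay is 150000 nM, within 60000 nM to 400000 nM, and most probably the assay will again report only a limit.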

Compound 4, half-maximal inhibitory concentration: > 100000 nM
Compound 4: a limit, no number (the forecaster's own chance of this, stated with the estimate: 80%); the middle value does not contradict the limit.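

In this assay compound 4 gives > 100000 nM, again a limit of the assay, so no step can be read between compound 1 and compound 4. The compounds shown leave open how benzyl and 4-methoxy-2-methylphenyl on an amide-type nitrogen compare, since all share one result: the limit of > 100000 nM in this assay, at which 4 of the 4 values shown sit.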